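Sulfonamide benzylamines: relocating the methoxy group on the benzyl ring

The source may hold more compounds than are shown below. What is called first, only, known or untested is meant among the compounds shown, and "the series" means these compounds.

Compound 1 `COc1ccc(CNCCCNS(=O)(=O)c2cc(C(F)(F)F)cc(C(F)(F)F)c2)cc1OC` gives 15000 nM in a functional assay on Capan-2 cells (Homo sapiens) for inhibition, read by MTT assay, with a stated time of 72 h; a higher number here means a weaker inhibitor of growth, a lower number a stronger inhibitor of growth. Compound 2 `CN(CCCNS(=O)(=O)c1cc(C(F)(F)F)cc(C(F)(F)F)c1)Cc1ccccc1` gives 46000 nM. Compound 3 `COc1ccc(CNCCCNS(=O)(=O)c2cc(C(F)(F)F)cc(C(F)(F)F)c2)cc1` gives 2400 nM.

Compound 3 stands lowest of the three, with a 6.3-fold lower number from compound 1 to compound 3 (0.80 log units; beyond the scatter) and a 19-fold lower number from compound 2 to compound 3 (1.28 log units; beyond the scatter). Compound 4 `COc1ccccc1CNCCCNS(=O)(=O)c1cc(C(F)(F)F)cc(C(F)(F)F)c1` differs from compound 3 by 2-methoxyphenyl in place of 4-methoxyphenyl on a saturated chain carbon bound to an amine nitrogen. Neither measured step bears directly on this change: the step from compound 1 to compound 3 removes a methoxy group, and the step from compound 2 to compound 3 alters the amine substituent; neither relocates a methoxy group on the ring. The step of a 1.7-fold higher number from compound 3 to compound 4 (0.22 log units; within the scatter) is therefore expected to be small, with direction uncertain and a higher number considered somewhat more likely. Compound 4 is estimated at 4000 nM, within 1500 nM to 15000 nM.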

Compound 4, concentration for 50% growth inhibition: 6000 nM
The estimate for compound 4 lay 1.5-fold (0.18 log units) below the measured number, within the range that was stated.
By their numbers in this assay, from the lowest: compound 3; then compound 4; then compound 1; then compound 2.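

In this assay, the position of the methoxy group on the benzyl ring matters, with a 2.5-fold higher number from compound 3 to compound 4 (0.40 log units; beyond the scatter), so 2-methoxyphenyl does not simply stand in for 4-methoxyphenyl at this place. Compound 4 still improves on two earlier compounds, with a 2.5-fold lower number from compound 1 to compound 4 (0.40 log units; beyond the scatter) and a 7.7-fold lower number from compound 2 to compound 4 (0.88 log units; beyond the scatter). No measurement here accounts for the preference for 4-methoxyphenyl.

As far as these compounds go, whether a hydroxyl group or a chlorine atom in place of the methoxy group would keep the number of compound 3 remains open. So does the effect of a longer chain in the 4-methoxybenzyl series.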